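A few compounds are considered here, and "the series" means these few. Any claim that something is new, unique, unknown or untested is made for them only; others in the source may bear on it.

In an ADME assay on AGS cells (Homo sapiens) for cytotoxicity, read by neutral red uptake, with a stated time of 24 h (a higher number here means a weaker inhibitor, a lower number a stronger inhibitor), compound 1 `CC(C)C(=O)Oc1c(C(C)C)cc2c3c1OC(=O)[C@@]31CCCC(C)(C)[C@@H]1CC2` gives 105000 nM, compound 2 `CCC(=O)Oc1c(C(C)C)cc2c3c1OC(=O)[C@@]31CCCC(C)(C)[C@@H]1CC2` gives 113000 nM, and compound 3 `CC(C)c1cc2c3c(c1OC(=O)c1ccccc1)OC(=O)[C@@]31CCCC(C)(C)[C@@H]1CC2` gives 503000 nM, the highest of the three numbers. Compound 4 `CC(C)c1cc2c3c(c1OC(=O)c1cccnc1)OC(=O)[C@@]31CCCC(C)(C)[C@@H]1CC2` differs from compound 3 at one place: pyridin-3-yl in place of phenyl on a carbonyl carbon. This puts pyridin-3-yl in place of phenyl on a carbonyl carbon. Two measured steps change the group on that carbonyl carbon: a 4.8-fold higher number from compound 1 to compound 3 (0.68 log units; beyond the scatter) and a 4.5-fold higher number from compound 2 to compound 3 (0.65 log units; beyond the scatter). Both are modest, whereas a 1.1-fold higher number from compound 1 to compound 2 (0.03 log units; within the scatter) stays within the scatter. Going by the values given here, no measured compound carries a ring with a hetero atom, so the guide is indirect. A step towards a lower number in this assay is expected, no larger than those two. The estimated step is a 2.1-fold lower number from compound 3 to compound 4 (0.32 log units; beyond the scatter). For compound 4 the estimated value is 240000 nM, with a range of 90000 nM to 600000 nM.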

Compound 4, half-maximal inhibitory concentration: 280000 nM
Estimate against measurement, compound 4: 1.2-fold (0.07 log units) below, within the range that was stated.
By their numbers in this assay, from the lowest: compounds 1 and 2 (each within the scatter of the next); then compounds 4 and 3 (each within the scatter of the next).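

Pyridin-3-yl, the only ring with a hetero atom among these compounds, stays level with phenyl on this carbonyl carbon in this assay, with a 1.8-fold lower number from compound 3 to compound 4 (0.25 log units; within the scatter). Both ring compounds stay apart from the chain compounds, with a 2.5-fold higher number from compound 2 to compound 4 (0.39 log units; beyond the scatter) and a 2.7-fold higher number from compound 1 to compound 4 (0.43 log units; beyond the scatter), so the ring nitrogen does not close that gap. No supporting data explain these numbers. From the compounds shown here alone, how a longer chain on this carbonyl carbon would read remains open, as does the effect of an amine or a carboxylic acid on the phenyl ring.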